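The source may hold more compounds than are shown below. What is called first, only, known or untested is meant among the compounds shown, and "the series" means these compounds.

In an in vitro functional assay on cells for antagonist activity at transient receptor potential cation channel subfamily V member 1 (Homo sapiens), read by reporter gene assay and calcium flux (on this read-out higher numbers stand for weaker inhibition and lower numbers for stronger inhibition), compound 2 `Nc1ccc2cccc(NC(=O)Nc3ccc(Cl)c(C(F)(F)F)c3)c2c1` gives 34 nM. Compound 1 `O=C(Nc1ccc(Cl)c(C(F)(F)F)c1)Nc1cccc2cc(O)ccc12` gives 18 nM in this assay, and the two numbers lie within the usual scatter of each other. Compound 3 `Nc1cc2c(NC(=O)Nc3ccc(Cl)c(C(F)(F)F)c3)cccc2cc1Cl` gives only > 1000 nM, which is a limit of the assay (the limit of > 1000 nM in this assay, at which 1 of the 3 values shown sits). Within the data shown here, the one measured step in this set, an at least 29-fold higher number from compound 2 to compound 3 (1.46 log units; beyond the scatter), placed a chloro group on an aromatic carbon. Compound 4 `CS(=O)(=O)Nc1ccc2cccc(NC(=O)Nc3ccc(Cl)c(C(F)(F)F)c3)c2c1` differs from compound 2 by methylsulfonyl in place of hydrogen on a nitrogen on an aromatic ring. Among the measured compounds shown here, that touches the amino nitrogen rather than an aromatic carbon, and no measured step addresses such a change, so the measured steps offer no guide here. With nothing pointing to a large shift, the expected step of a 1.2-fold higher number from compound 2 to compound 4 (0.07 log units; within the scatter) is small, and compound 4 is estimated at 40 nM, between 10 nM and 200 nM.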

Compound 4, half-maximal inhibitory concentration: > 1000 nM
Compound 4: a limit, no number; the forecaster's own chance of this, stated with the estimate: 5%; at least 25-fold (1.39 log units) between middle value and limit.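

Swapping amino for methanesulfonamido gives an at least 29-fold higher number from compound 2 to compound 4 (1.46 log units; beyond the scatter), so the amino nitrogen, which no earlier step touched, does not accept this change in this assay. The value of compound 4 is a limit and not a number, so the true size of the loss remains unknown: the limit of > 1000 nM in this assay, at which 2 of the 4 values shown sit.

Compound 2 thus loses activity beyond the scatter with a chloro group on an aromatic carbon and with methylsulfonyl on the nitrogen. Still open, from the compounds shown here alone, is whether a methyl or an acetyl group on this nitrogen would stay close to compound 2 or also reach the limit.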